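The source may hold more compounds than are shown below. What is called first, only, known or untested is meant among the compounds shown, and "the series" means these compounds.

Working notes on the series.

Compound 1 `c1cncc(-c2ccccc2OCC2=NCCN2)c1` gives 79.4 nM in a functional assay for activation of Alpha-1B adrenergic receptor (Homo sapiens), read by calcium flux (a lower number here means that less compound is needed, a higher number that more compound is needed for the effect), and compound 2 `c1coc(-c2ccccc2OCC2=NCCN2)c1` gives 10 nM; the step of a 7.9-fold lower number from compound 1 to compound 2 (0.90 log units; beyond the scatter) is the only fully readable one in the set. For compound 3 `Cc1csc(-c2ccccc2OCC2=NCCN2)n1` this assay reports only a limit, < 100000 nM, so compound 3 stands at a limit rather than at a number. The steps a step that the limit leaves unreadable from compound 1 to compound 3 and a step that the limit leaves unreadable from compound 2 to compound 3 therefore give no size, as the limit of < 100000 nM in this assay, at which 1 of the 3 values shown sits, sets the boundary. Compound 4 `Cc1cnsc1-c1ccccc1OCC1=NCCN1` carries 4-methyl-1,2-thiazol-5-yl in place of 4-methyl-1,3-thiazol-2-yl on an aromatic carbon; the two have the same atoms, joined differently. Among the compounds with values here, no measured step speaks to this rearrangement, so for compound 4 the expected value in this assay is set broadly at 3000 nM, between 100 nM and 100000 nM; the implied step that the limit leaves unreadable from compound 3 to compound 4 is an estimate only.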

Compound 4, half-maximal effective concentration: < 100000 nM
Compound 4: no number, only a limit; the forecaster's own chance of this, stated with the estimate: 30%; the middle value lies beyond the limit too.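

Within the data shown here, compound 3 and compound 4 both stand only at a limit, so no step to compound 4 can be read from any of the other compounds: the limit of < 100000 nM in this assay, at which 2 of the 4 values shown sit. The compounds shown leave open whether 4-methyl-1,2-thiazol-5-yl and 4-methyl-1,3-thiazol-2-yl differ at all in this assay.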